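Aryl-chloro deletion in a fatty acid receptor 1 agonist series

The source may hold more compounds than are shown below. What is called first, only, known or untested is meant among the compounds shown, and "the series" means these compounds.

The series shares a core in which a propargylic acid side chain is carried on an aryloxymethyl-substituted fused bicyclic ether; members differ in stereochemistry and in the placement of a chloro group on the fused aromatic ring. In a functional assay on HEK293 cells for agonist activity at Free fatty acid receptor 1 (Homo sapiens), read by fluorescence and calcium flux, with a stated time of 10 min (a higher number here means a larger maximal response, a lower number a smaller maximal response), compound 1 `CC#CC(CC(=O)O)c1ccc(OCC2COc3ccc(Cl)cc3O2)cc1` gives 104%. Compound 2 `CC#C[C@@H](CC(=O)O)c1ccc(OC[C@H]2COc3c(Cl)cccc3O2)cc1` gives 81% in this assay, and compound 3 `CC#C[C@@H](CC(=O)O)c1ccc(OC[C@H]2COc3cc(Cl)ccc3O2)cc1` gives 80%. Among the three numbers compound 3 stands at the bottom, but the gap to compound 2 lies within the usual scatter, so the two cannot be separated on this read-out; only compound 1 sits beyond the scatter, with the higher maximal response. Among the compounds with values here, no two measured compounds differ in a single place, so no isolated structural step is available as a reference.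

Compound 4 `CC#C[C@@H](CC(=O)O)c1ccc(OC[C@H]2COc3ccccc3O2)cc1` remains to be measured in this assay. Relative to compound 3 the change is hydrogen in place of chloro on an aromatic carbon. Without a comparable measured pair, the maximal response is expected to shift little, with the step of a number 6 percentage points higher from compound 3 to compound 4 (within the scatter) estimated to stay within or close to the scatter and tending, if anything, upward. For compound 4 the expected value in this assay is 86%, with a range from 70% to 102%.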

Compound 4, largest response reached (Emax), in percent of the reference or control that the assay uses: 70%
The estimate for compound 4 lay 16 percentage points above the measured number, and the stated range covers the measured number.
By their numbers in this assay, from the lowest: compounds 4, 3 and 2 (each within the scatter of the next, the first and the last beyond it); then compound 1.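

Within the data shown here, exchanging chloro for hydrogen on the aromatic carbon that is meta to a fused ring and para to a fused ring gives the first single-place step in this assay: a number 10 percentage points lower from compound 3 to compound 4 (within the scatter), so at this place the two substituents cannot be separated on maximal response. The same exchange at the chloro placement of compound 2 gives a modest step beyond the scatter, a number 11 percentage points lower from compound 2 to compound 4 (beyond the scatter), and the read-out therefore depends on the chloro group at that placement, though only slightly, while compound 4 still gives 70% with no chloro group at all. No measurement available here explains either step.

The compounds shown leave open how other groups at these aromatic carbons, such as fluoro, methyl or methoxy, would compare with chloro and hydrogen. They also leave open the source of the higher number of compound 1, at 104%, since it differs from each of the other three compounds in more than one place, including its undefined stereochemistry.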